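This account rests on a few compounds, and the source may have more. Where it says the series, first, only, none or still open, it means among the compounds named here.

In a functional assay on A549 cells (Homo sapiens) for antiproliferative activity, read by MTT assay, with a stated time of 48 h (on this read-out higher numbers stand for weaker inhibition and lower numbers for stronger inhibition), compound 3 `Cc1ccccc1-n1nncc1CN1C(=O)C2(C(C#N)=C(N)Oc3c(N)cc4nc5ccccc5nc4c32)c2ccccc21` gives 31700 nM, the only actual number among the three results shown. Compound 1 `COc1ccc(-n2nncc2CN2C(=O)C3(C(C#N)=C(N)Oc4c3c3nc5ccccc5nc3c3ccccc43)c3ccccc32)cc1` gives > 50000 nM, which is a limit of the assay rather than a number. Compound 2 `CC(=O)Nc1ccc(-n2nncc2CN2C(=O)C3(C(C#N)=C(N)Oc4c3c3nc5ccccc5nc3c3ccccc43)c3ccccc32)cc1` likewise gives > 50000 nM, again a limit. Among the compounds with values here, the single step between measured compounds, a step that the two limits leave unreadable from compound 1 to compound 2, cannot be sized because of the limit of > 50000 nM in this assay, at which 2 of the 3 values shown sit. Compound 4 `COc1ccccc1-n1nncc1CN1C(=O)C2(C(C#N)=C(N)Oc3c(N)cc4nc5ccccc5nc4c32)c2ccccc21` differs from compound 3 by methoxy in place of methyl on an aromatic carbon. Within the data shown here, no measured step bears on this change, so nothing beyond the usual scatter is expected in this assay. Compound 4 is therefore estimated at 35000 nM, with a range from 12000 nM to 100000 nM. The expected step of a 1.1-fold higher number from compound 3 to compound 4 (0.04 log units; within the scatter) is accordingly small.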

Compound 4, half-maximal inhibitory concentration: 37500 nM
Beside the measured number, compound 4's estimate is 1.1-fold (0.03 log units) below it, within the range that was stated.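

In this assay the change from 2-methylphenyl to 2-methoxyphenyl gives a 1.2-fold higher number from compound 3 to compound 4 (0.07 log units; within the scatter) and so leaves methyl and methoxy at this place, ortho to a large group, indistinguishable. This is the first step among these compounds that can be read, since the only earlier step cannot be sized: the limit of > 50000 nM in this assay, at which 2 of the 4 values shown sit.

Only methyl and methoxy are shown at this place, so whether an amine, a hydroxyl or a fluorine there would move the number beyond the scatter stays open. Also open, as far as these compounds go, is whether the same change would behave alike on the core of compound 1.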